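Replacing the dihydroxyphenyl of compound 2 with a bromo-hydroxyphenyl

This account rests on a few compounds, and the source may have more. Where it says the series, first, only, none or still open, it means among the compounds named here.

The measured compounds:
compound 1, `Cc1c(C(=O)N/N=C\c2cccc(F)c2)oc2cccc(O)c12` — in a functional assay on PC-3 cells (Homo sapiens) for inhibition (a higher number here means a weaker inhibitor, a lower number a stronger inhibitor), compound 1 gives >= 40000 nM, which is a limit of the assay and not a number.
compound 2, `Cc1c(C(=O)N/N=C\c2cc(O)ccc2O)oc2cccc(O)c12` — in this assay compound 2 gives 95500 nM.
compound 3, `Cc1c(C(=O)N/N=C\c2cc(Cl)cc(Cl)c2O)oc2cccc(O)c12` — in this assay compound 3 gives 9590 nM.

Of the two actual numbers, compound 2 stands highest, meaning it is the weaker inhibitor; the nearest number, that of compound 3, lies well below it, and that gap is beyond the scatter. Compound 1 sits at a limit, (the limit of >= 40000 nM in this assay, at which 1 of the 3 values shown sits), so the step from compound 1 to compound 2, a step that the limit leaves unreadable from compound 1 to compound 2, cannot be sized.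

Compound 4, `Cc1c(C(=O)N/N=C\c2ccc(Br)cc2O)oc2cccc(O)c12`, differs from compound 2 in one place: 4-bromo-2-hydroxyphenyl in place of 2,5-dihydroxyphenyl on a carbon with a double bond to nitrogen. Going by the values given here, no measured step covers this exchange directly, since the only step between neighbouring compounds is the unreadable one from compound 1. What the data do show is that compound 3, which also carries a hydroxyphenyl bearing halogens, gives 9590 nM, far below compound 2. By that comparison a step downward, toward stronger inhibition, is expected for compound 4, estimated as a 3.8-fold lower number from compound 2 to compound 4 (0.58 log units; beyond the scatter). Compound 4 is therefore expected at about 25000 nM, with a likely range from 8000 nM to 80000 nM.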

Compound 4, half-maximal inhibitory concentration: 2050 nM
The estimate for compound 4 lay 12-fold (1.09 log units) above the measured number; measured number below the stated range.
By their numbers in this assay, from the lowest: compound 4; then compound 3; then compound 2.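

Going by these compounds alone, at this place, on a carbon with a double bond to nitrogen, one exchange of 2,5-dihydroxyphenyl for 4-bromo-2-hydroxyphenyl in this assay gives a 47-fold lower number from compound 2 to compound 4 (1.67 log units; beyond the scatter), the first step here whose size can be read between two actual numbers. The same group also sets compound 4 apart from the 3-fluorophenyl of the earlier series, with an at least 19-fold lower number from compound 1 to compound 4 (1.29 log units; beyond the scatter), and with compound 4 at 2050 nM and compound 3 at 9590 nM, the dichlorinated compound no longer marks the low end of the printed values. That second step has a known size on one side only, as the number for compound 1 is a limit of the assay and not a number: the limit of >= 40000 nM in this assay, at which 1 of the 4 values shown sits.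

The exchange brings in a bromine and takes away a hydroxyl in one move, and the compounds shown cannot tell which of the two accounts for the step. A plain 2-hydroxyphenyl would separate them, and an amine or a carboxylic acid on this ring would show whether groups of a very different kind are tolerated at this place.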